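Replacing cyclopropylcarbonyl with 2-ethoxyethyl on an amine nitrogen

A few compounds are considered here, and "the series" means these few. Any claim that something is new, unique, unknown or untested is made for them only; others in the source may bear on it.

Measured in a functional assay on MV4-11 cells (Homo sapiens) for antiproliferative activity, read by CellTiter-Glo, with a stated time of 72 h; a higher number here means a weaker inhibitor of growth, a lower number a stronger inhibitor of growth:
- Compound 1 `Clc1cnc(Nc2ccccc2)cc1-c1csc(NCC2CCOCC2)n1`: > 10000 nM
- Compound 2 `O=C(N[C@H]1CC[C@H](Nc2cc(-c3csc(NCC4CCOCC4)n3)c(Cl)cn2)CC1)C1CC1`: > 10000 nM

Compound 2 gives > 10000 nM, which is a limit of the assay and not a number. Its standing is the limit of > 10000 nM in this assay, at which 2 of the 2 values shown sit. Within the data shown here, no measured pair yet shows how a single structural change moves the result in this assay.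

Compound 3 `CCOCCN[C@H]1CC[C@H](Nc2cc(-c3csc(NCC4CCOCC4)n3)c(Cl)cn2)CC1` keeps the core of compound 2 and alters one group: 2-ethoxyethyl in place of cyclopropylcarbonyl on an amine nitrogen. In words, 2-ethoxyethyl stands in place of cyclopropylcarbonyl on an amine nitrogen, and an open chain replaces a ring.

The expected change is an at least 25-fold lower number from compound 2 to compound 3 (1.39 log units; beyond the scatter), a large step toward stronger inhibition of growth, though this expectation is uncertain. For compound 3 the estimated value is 400 nM, with an expected range from 40 nM to 6000 nM.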

Compound 3, concentration for 50% growth inhibition: 497 nM
Estimate against measurement, compound 3: 1.2-fold (0.09 log units) below, and the stated range covers the measured number.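

In this assay, putting 2-ethoxyethyl in place of cyclopropylcarbonyl on this amine nitrogen gives an at least 20-fold lower number from compound 2 to compound 3 (1.30 log units; beyond the scatter), which shows that the group here can strongly change growth inhibition, something compound 1 and compound 2 alone could not show. From the compounds shown here alone, the value of compound 2, > 10000 nM, is a limit of the assay and not a number, so the full size of the step is unknown. Compound 3 is the only one of the three compounds off that limit, and the other two remain on it: the limit of > 10000 nM in this assay, at which 2 of the 3 values shown sit.

The change removes the carbonyl and the three-membered ring together and adds a chain with an ether oxygen, so the compounds shown cannot say which of these matters. A cyclopropylmethyl group or a plain propyl chain on this nitrogen would help to separate them.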